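The compounds below may be only part of what the source reports. "The series", "measured", "known", "first", "only" and "open" are said of these compounds alone.

Compound 1 `CCCCc1sc(-c2ccc(OCCCN3CCCC3)cc2)nc1-c1ccc(Oc2ccc(Cl)cc2)cc1` was tested in an assay on isolated protein for antagonist activity at advanced glycosylation end product-specific receptor (Homo sapiens), read by ELISA, with a stated time of 60 min, tested at 10 uM (on this read-out higher numbers stand for more inhibition at the one concentration tested (going by the name of the read-out) and lower numbers for less inhibition), and gave 47.8%. Two related compounds give a sense of the spread: compound 2 `CCCCc1sc(-c2ccc(Oc3ccc(Cl)cc3)cc2)nc1-c1ccc(OCCCN(CC)CC)cc1` gives 57% in this assay, and compound 3 `CCCCc1nc(-c2ccc(Oc3ccc(Cl)cc3)cc2)sc1-c1ccc(OCCCN(CC)CC)cc1` gives 57.1%. Compound 1 has the smallest of these three numbers, but both other numbers lie within the usual scatter of it, so the three cannot be told apart with confidence.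

Compound 4 `CCCCc1sc(-c2ccc(OCCCN3CCCCC3)cc2)nc1-c1ccc(Oc2ccc(Cl)cc2)cc1` differs from compound 1 in one place: piperidin-1-yl in place of pyrrolidin-1-yl on a saturated chain carbon, three bonds along the chain from an oxygen on an aromatic ring. The ring that enters is one member larger than the one that leaves, and nothing else changes. Among the compounds with values here, no measured pair shows what such a ring enlargement does here, so the expected step is small, in either direction, and not beyond the scatter. The step from compound 1 to compound 4 is estimated as a number 2.2 percentage points higher from compound 1 to compound 4 (within the scatter). Compound 4 is accordingly expected to give about 50% in this assay, with a range from 36% to 64%.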

Compound 4, a percentage reported as inhibition, at one concentration (the size of the read-out at that concentration, not a potency): 59.2%
Compound 4: middle estimate off by 9.2 percentage points, on the low side, within the range that was stated.
By their numbers in this assay, from the lowest: compounds 1, 2, 3 and 4 (each within the scatter of the next, the first and the last beyond it).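

Within the data shown here, replacing 3-(pyrrolidin-1-yl)propyl with 3-(piperidin-1-yl)propyl provides the first comparison here of compounds that differ in one place: in this assay the change gives a number 11.4 percentage points higher from compound 1 to compound 4 (beyond the scatter). A ring one member larger at this position can therefore move the number beyond the usual scatter, although this rests on a single pair. Nothing available explains the step. The compounds shown leave open what morpholin-4-yl or azepan-1-yl would give on the same chain, and whether a shorter or longer chain would change the effect of this ring enlargement.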